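Replacing the Dichlorophenyl Group of Compound 1

The compounds below may be only part of what the source reports. "The series", "measured", "known", "first", "only" and "open" are said of these compounds alone.

The compounds measured so far (a functional assay on K562 cells (Homo sapiens) for cytotoxicity, read by propidium iodide staining, with a stated time of 48 h; a higher number here means that more compound is tolerated, a lower number that less compound is tolerated) are:
- compound 1 (`O=C(CN1C(=O)S/C(=C/c2ccco2)C1=O)Nc1ccc(Cl)c(Cl)c1`) gives 43300 nM
- compound 2 (`O=C(CN1C(=O)S/C(=C/c2ccco2)C1=O)Nc1ccc(Cl)cc1C(F)(F)F`) gives > 100000 nM (a limit, not a number)
- compound 3 (`Cc1cccc2sc(NC(=O)CN3C(=O)S/C(=C/c4ccco4)C3=O)nc12`) gives 97100 nM

Compound 1 has the lower of the two actual numbers, and compound 3 lies higher by more than the usual scatter. Compound 2 reached only a limit (> 100000 nM) and has no exact number.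

Compound 4 (`Cc1ccc(NC(=O)CN2C(=O)S/C(=C/c3ccco3)C2=O)cc1`) has not been measured yet. The change from compound 1 is 4-methylphenyl in place of 3,4-dichlorophenyl on an amide-type nitrogen and in words it is 4-methylphenyl in place of 3,4-dichlorophenyl on an amide-type nitrogen. Among the measured compounds shown here, no measured pair shows this change directly, so the estimate rests on the overall spread of the series. Compound 1 (43300 nM) already sits at the low end, so a small rise seems more likely than a fall. The expected step (a 1.6-fold higher number from compound 1 to compound 4 (0.21 log units; within the scatter)) is upward and not clearly beyond the scatter. For compound 4 the estimated value is 70000 nM with 30000 nM to 140000 nM as its expected range.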

Compound 4, half-maximal cytotoxic concentration: > 100000 nM
Compound 4: only a limit was reported; the forecaster's own chance of this, stated with the estimate: 25%; middle value at least 1.4-fold (0.15 log units) from the limit.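

Among the compounds shown here, replacing 3,4-dichlorophenyl with 4-methylphenyl on the amide-type nitrogen gives an at least 2.3-fold higher number from compound 1 to compound 4 (0.36 log units; beyond the scatter) in this assay, the first single-place change, and it lies beyond the scatter with the rest of the molecule held constant. Compound 4 gives > 100000 nM, which is a limit and not a number. The step is therefore only a minimum, and its true size stays unknown because of this shared limit: the limit of > 100000 nM in this assay, at which 2 of the 4 values shown sit.

The change removes both chlorines and adds a methyl group, so the compounds shown cannot tell whether losing one chlorine or losing both matters, or whether the methyl group plays any part. A 4-chlorophenyl or 3-chlorophenyl group on the same nitrogen would help separate these possibilities, as would an unsubstituted phenyl group.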